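A few compounds are considered here, and "the series" means these few. Any claim that something is new, unique, unknown or untested is made for them only; others in the source may bear on it.

Measured so far in a functional assay on cells for inhibition, with Murine T-cell line (Mus musculus) as the target; on this read-out higher numbers stand for weaker inhibition and lower numbers for stronger inhibition:
compound 1, `CC[C@@H]1/C=C(\C)C[C@H](C)C[C@H](OC)[C@H]2O[C@@](O)(C(=O)C(=O)N3CCCC[C@H]3C(=O)O[C@H](/C(C)=C/[C@@H]3CC[C@@H](Oc4ccc(C(F)(F)F)cc4)[C@H](OC)C3)[C@H](C)[C@@H](O)CC1=O)[C@H](C)C[C@@H]2OC`: 35.8 nM
compound 2, `CC[C@@H]1/C=C(\C)C[C@H](C)C[C@H](OC)[C@H]2O[C@@](O)(C(=O)C(=O)N3CCCC[C@H]3C(=O)O[C@H](/C(C)=C/[C@@H]3CC[C@@H](Oc4ccc(C)cc4)[C@H](OC)C3)[C@H](C)[C@@H](O)CC1=O)[C@H](C)C[C@@H]2OC`: 2.7 nM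

Going by the values given here, compound 2 stands lowest of these two numbers, with compound 1 the only other value. Among the compounds with values here, the single measured step, a 13-fold lower number from compound 1 to compound 2 (1.12 log units; beyond the scatter), shows that the group at this position can shift the read-out strongly. Compound 3, `CC[C@@H]1/C=C(\C)C[C@H](C)C[C@H](OC)[C@H]2O[C@@](O)(C(=O)C(=O)N3CCCC[C@H]3C(=O)O[C@H](/C(C)=C/[C@@H]3CC[C@@H](Oc4ccc(F)cc4)[C@H](OC)C3)[C@H](C)[C@@H](O)CC1=O)[C@H](C)C[C@@H]2OC`, differs from compound 2 by fluoro in place of methyl on an aromatic carbon. Within the data shown here, no measured step exchanges methyl for fluoro, so the direction is uncertain; a small to modest step is expected, a 1.9-fold higher number from compound 2 to compound 3 (0.27 log units; within the scatter). Compound 3 is estimated at 5 nM, within a range from 1.5 nM to 20 nM.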

Compound 3, half-maximal inhibitory concentration: 3.4 nM
Estimate against measurement, compound 3: 1.5-fold (0.17 log units) above, and the stated range covers the measured number.
By their numbers in this assay, from the lowest: compounds 2 and 3 (each within the scatter of the next); then compound 1.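

In this assay, fluoro in place of methyl gives a 1.3-fold higher number from compound 2 to compound 3 (0.10 log units; within the scatter), so the two groups cannot be told apart at this position. Fluoro in place of trifluoromethyl gives an 11-fold lower number from compound 1 to compound 3 (1.02 log units; beyond the scatter), which matches the earlier step from trifluoromethyl to methyl and leaves trifluoromethyl as the one group of the three with clearly weaker inhibition. Nothing available here explains why these groups compare as they do. Still open, going by these compounds, is whether a plain hydrogen, a hydroxyl group or an amine in the same place would match methyl and fluoro or fall back towards trifluoromethyl.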